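Fluoromethyl on a chain carbon, carbamate and amide compared

The source may hold more compounds than are shown below. What is called first, only, known or untested is meant among the compounds shown, and "the series" means these compounds.

Compound 1 `CCNC(=O)Nc1sc2ccccc2c1C(=O)N1CCN(C2CCN(C(=O)OC(C)C)CC2)CC1`: 208 nM
Compound 2 `CCNC(=O)Nc1sc2ccccc2c1C(=O)N1CCN(C2CCN(C(=O)OC(C)(C)CF)CC2)CC1`: 61 nM
Compound 3 `CCNC(=O)Nc1sc2cc(C)ccc2c1C(=O)N1CCN(C2CCN(C(=O)C(C)C)CC2)CC1`: 628 nM

In a functional assay on HepG2 cells (Homo sapiens) for inhibition, read by scintillation counting, with a stated time of 2 h (a higher number here means a weaker inhibitor, a lower number a stronger inhibitor), compound 3 gives the highest number of the three, and the difference between the core of compound 3 and that of compound 1 is not broken down here. The step of a 3.4-fold lower number from compound 1 to compound 2 (0.53 log units; beyond the scatter) followed the change (fluoromethyl in place of hydrogen on a saturated chain carbon bound to an oxygen next to a carbonyl group and two saturated chain carbons). Compound 4 `CCNC(=O)Nc1sc2cc(C)ccc2c1C(=O)N1CCN(C2CCN(C(=O)C(C)(C)CF)CC2)CC1` carries the same kind of change, (fluoromethyl in place of hydrogen on a saturated chain carbon bound to a carbonyl carbon and two saturated chain carbons), but the place is not identical: in compound 2 the carbon is bound to an oxygen next to a carbonyl group, in compound 4 to a carbonyl carbon. Resting on that single earlier step in compound 1 and compound 2, he expects a step of comparable size, a 2.6-fold lower number from compound 3 to compound 4 (0.42 log units; beyond the scatter), and estimates compound 4 at 240 nM, between 110 nM and 550 nM.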

Compound 4, half-maximal inhibitory concentration: 73 nM
The estimate for compound 4 lay 3.3-fold (0.52 log units) above the measured number, and the stated range ends above it.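

In this assay, fluoromethyl in place of hydrogen on a saturated chain carbon bound to a carbonyl carbon and two saturated chain carbons gave an 8.6-fold lower number from compound 3 to compound 4 (0.93 log units; beyond the scatter). Among these compounds, the change therefore lowered the number on both cores, and the two steps agree in size within the scatter: the same change on two cores in this assay, a 3.4-fold lower number (0.53 log units; beyond the scatter) from compound 1 to compound 2 and an 8.6-fold lower number (0.93 log units; beyond the scatter) from compound 3 to compound 4, 2.5-fold (0.40 log units) apart, within the scatter of two such steps This rests on only two pairs, in which the carbon carrying the change is bound to an oxygen in one and to a carbonyl carbon in the other, so it does not show that the change would carry over to other cores.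

The compounds shown leave open how much of the step belongs to the fluorine and how much to the added carbon, which a tert-butyl group in the same place would address. A trifluoromethyl group in place of the fluoromethyl would test whether further fluorine changes the result.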